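Aryl substituent changes on the shared core: methyl to trifluoromethyl

The compounds below may be only part of what the source reports. "The series", "measured", "known", "first", "only" and "open" are said of these compounds alone.

Measured so far in a functional assay on HL-60 cells (Homo sapiens) for activation, read by flow cytometry, with a stated time of 4 days; on this read-out lower numbers stand for an effect already at smaller amounts and higher numbers for an effect only at larger amounts of compound:
compound 1 `Fc1ccc(-c2cc3c(cn2)ncn3-c2ccc(OC(F)F)cc2)c(Cl)c1` gives 90 nM
compound 2 `CCc1ccccc1-c1cc2c(cn1)ncn2-c1ccc(OC(F)F)cc1` gives 2900 nM
compound 3 `Cc1ccc(-c2cc3c(cn2)ncn3-c2ccc(OC(F)F)cc2)c(C)c1` gives 180 nM

Compound 3 sits second highest of the three numbers; its nearest neighbour is compound 1, with a 2.0-fold higher number from compound 1 to compound 3 (0.30 log units; within the scatter), and its furthest is compound 2, with a 16-fold lower number from compound 2 to compound 3 (1.21 log units; beyond the scatter). Compound 4 `Cc1cc(C(F)(F)F)ccc1-c1cc2c(cn1)ncn2-c1ccc(OC(F)F)cc1` differs from compound 3 in one place: trifluoromethyl in place of methyl on an aromatic carbon.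

Going by the values given here, no measured step isolates this exchange. The two steps that touch the same aryl ring are a 2.0-fold higher number from compound 1 to compound 3 (0.30 log units; within the scatter), which is within the scatter, and a 16-fold lower number from compound 2 to compound 3 (1.21 log units; beyond the scatter), which is large and also changes the second group on the ring. As far as these compounds go, the step from compound 1 to compound 3 shows that a fluorine or a methyl at the place "para to a large group" give comparable numbers; a trifluoromethyl there is untested. The expectation is therefore a step no larger than the scatter, or a modest rise in the number, and the estimate for compound 4 is 250 nM, range 80 nM to 800 nM, meaning a 1.4-fold higher number from compound 3 to compound 4 (0.14 log units; within the scatter).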

Compound 4, half-maximal effective concentration: 1000 nM
The estimate for compound 4 lay 4.0-fold (0.60 log units) below the measured number; the whole stated range lies below it.
By their numbers in this assay, from the lowest: compounds 1 and 3 (each within the scatter of the next); then compound 4; then compound 2.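

Working notes: in this assay, the place para to a large group is not indifferent to what sits there, as trifluoromethyl in place of methyl gives a 5.6-fold higher number from compound 3 to compound 4 (0.74 log units; beyond the scatter). The earlier step, a 2.0-fold higher number from compound 1 to compound 3 (0.30 log units; within the scatter), changed both groups on this ring and left the number within the scatter, so it gave no sign that a single exchange at this place could move the number beyond it. No measurement on the compounds shown explains the rise.

Open, as far as these compounds go, is what a methoxy, a nitrile or an amine at this place would give, and so whether the number follows the heavy-atom count or is particular to trifluoromethyl. Also open, from the compounds shown here alone, is whether the exchange gives a step of similar size when chlorine takes the place of the remaining methyl on the ring.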